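The source may report more compounds than this note shows. Statements on the series, on what has been measured and on what is new or still open speak of the compounds shown alone.

Compound 1 `O=C1/C(=C/c2ccncc2)CN(S(=O)(=O)c2ccc(Br)cc2)C/C1=C\c1ccccc1F` gives 12600 nM in a functional assay on SMMC-7721 cells (Homo sapiens) for cytotoxicity, read by MTT assay, with a stated time of 24 h; on this read-out lower numbers stand for stronger inhibition and higher numbers for weaker inhibition. Compound 2 `N#Cc1ccc(S(=O)(=O)N2C/C(=C\c3ccncc3)C(=O)/C(=C/c3ccccc3F)C2)cc1` differs from compound 1 by cyano in place of bromo on an aromatic carbon, and in this assay compound 2 gives 16200 nM, a step of a 1.3-fold higher number from compound 1 to compound 2 (0.11 log units; within the scatter). Compound 3 `O=C1/C(=C/c2ccncc2)CN(S(=O)(=O)c2ccc(Br)cc2)C/C1=C\c1ccccc1C(F)(F)F` carries a different core, the difference being (trifluoromethyl in place of fluoro on an aromatic carbon); in this assay compound 3 gives 10500 nM, a step of a 1.2-fold lower number from compound 1 to compound 3 (0.08 log units; within the scatter). All three numbers sit close together.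

Compound 4 `N#Cc1ccc(S(=O)(=O)N2C/C(=C\c3ccncc3)C(=O)/C(=C/c3ccccc3C(F)(F)F)C2)cc1` has not yet been measured in this assay. It differs from compound 3 by cyano in place of bromo on an aromatic carbon, the same change already made from compound 1 to compound 2, with the same surroundings. The step expected from compound 3 to compound 4 is a 1.3-fold higher number from compound 3 to compound 4 (0.11 log units; within the scatter), resting on the step of a 1.3-fold higher number from compound 1 to compound 2 (0.11 log units; within the scatter) seen on the core of compound 1. Compound 4 is therefore estimated at 13500 nM, expected to lie between 8000 nM and 24000 nM.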

Compound 4, half-maximal inhibitory concentration: 9610 nM
Compound 4: middle estimate off by 1.4-fold (0.15 log units), on the high side; the measured number falls inside the stated range.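

In this assay, cyano in place of bromo gives a 1.1-fold lower number from compound 3 to compound 4 (0.04 log units; within the scatter), and this step agrees with the earlier one on the core of compound 1: the same change on two cores in this assay, a 1.3-fold higher number (0.11 log units; within the scatter) from compound 1 to compound 2 and a 1.1-fold lower number (0.04 log units; within the scatter) from compound 3 to compound 4, 1.4-fold (0.15 log units) apart, within the scatter of two such steps. Trifluoromethyl in place of fluoro gives a 1.7-fold lower number from compound 2 to compound 4 (0.23 log units; within the scatter), and this step also agrees with its earlier counterpart: the same change on two cores in this assay, a 1.2-fold lower number (0.08 log units; within the scatter) from compound 1 to compound 3 and a 1.7-fold lower number (0.23 log units; within the scatter) from compound 2 to compound 4, 1.4-fold (0.15 log units) apart, within the scatter of two such steps. Going by these compounds alone, both changes therefore carry between these two cores without a detectable difference, but every step lies within the scatter, so this shows only that neither change moves the number measurably here, not that a larger step would carry over in the same way.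

Still open, on these data alone, is whether an amine or a carboxylic acid in place of the cyano of the 4-cyanophenyl group would give a step beyond the scatter. If so, it would also remain to be seen whether that step carries from one core to the other.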